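Working notes: methyl in place of dimethylamino

The source may hold more compounds than are shown below. What is called first, only, known or untested is meant among the compounds shown, and "the series" means these compounds.

Measured in a functional assay on Jurkat cells (Homo sapiens) for antiproliferative activity, read by MTT assay, with a stated time of 72 h; on this read-out lower numbers stand for stronger inhibition and higher numbers for weaker inhibition:
- compound 1 `CNc1nc(-c2cc(OC)c(OC)c(OC)c2)c(-c2ccc3ccccc3c2)s1`: 51.1 nM
- compound 2 `COc1cc(-c2nc(N(C)C)sc2-c2ccc3ccccc3c2)cc(OC)c1OC`: 836 nM
- compound 3 `CCOc1ccc(-c2sc(N(C)C)nc2-c2cc(OC)c(OC)c(OC)c2)cc1`: 4150 nM

Compound 2 stands second highest of these three numbers. Compound 4 `COc1cc(-c2nc(C)sc2-c2ccc3ccccc3c2)cc(OC)c1OC` differs from it as follows: methyl in place of dimethylamino on an aromatic carbon. The closest evidence is a 16-fold higher number from compound 1 to compound 2 (1.21 log units; beyond the scatter), a large step made on the nitrogen of the group that leaves here. The other step, a 5.0-fold higher number from compound 2 to compound 3 (0.70 log units; beyond the scatter), is modest and replaces the naphthalen-2-yl group, which compound 4 keeps. For the measured compounds named here, no measured compound carries methyl on that aromatic carbon, so the direction is poorly founded. A modest rise in this assay is expected. The estimated change is a 1.6-fold higher number from compound 2 to compound 4 (0.19 log units; within the scatter). For compound 4 the estimated value is 1300 nM, with an expected range of 250 nM to 6000 nM.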

Compound 4, half-maximal inhibitory concentration: 48.6 nM
Compound 4: the middle estimate sits 27-fold (1.43 log units) above what was measured; the measured number lies below the stated range.
By their numbers in this assay, from the lowest: compounds 4 and 1 (each within the scatter of the next); then compound 2; then compound 3.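

In this assay dimethylamino on this aromatic carbon stands apart: methyl in its place gives a 17-fold lower number from compound 2 to compound 4 (1.24 log units; beyond the scatter) and shows that an amino nitrogen is not required here for a number of this size. Methyl in place of methylamino gives a 1.1-fold lower number from compound 1 to compound 4 (0.02 log units; within the scatter) and leaves those two groups indistinguishable at this position. No measurement at hand accounts for the gap between dimethylamino and the two smaller groups.

Open, as far as these compounds go, is whether hydrogen, an unsubstituted amine or a longer chain such as ethyl on this carbon would hold the number at that level. Also open, from the compounds shown here alone, is whether methyl gives a similar step with 4-ethoxyphenyl in place of naphthalen-2-yl.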